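Branching the sulfonyl chain in an adrenergic binding series

The compounds below may be only part of what the source reports. "The series", "measured", "known", "first", "only" and "open" are said of these compounds alone.

Of the compounds shown here, three sharing one core have been measured in an assay on isolated protein (Cricetulus griseus) for binding affinity to Alpha-1B adrenergic receptor (Mesocricetus auratus), read by radioligand binding; on this read-out lower numbers stand for stronger inhibition and higher numbers for weaker inhibition. Compound 1, `CCCS(=O)(=O)Nc1cccc2c1CCCC2c1c[nH]cn1`, is known in this assay only as a limit, < 10000 nM; the limit of < 10000 nM in this assay, at which 1 of the 3 values shown sits, marks where it sits, so its exact place among the three cannot be fixed. Compound 2, `CS(=O)(=O)Nc1cccc2c1CCCCC2c1c[nH]cn1`, gives 10000 nM in this assay. Compound 3, `CCS(=O)(=O)Nc1cccc2c1CCC2c1c[nH]cn1`, gives 2000 nM in this assay. For the measured compounds named here, no pair of these differs in one place alone, so no single step between measured compounds can be read.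

Compound 4, `CC(C)S(=O)(=O)Nc1cccc2c1CCCC2c1c[nH]cn1`, has not been measured. It differs from compound 1 by isopropyl in place of propyl on a sulfonyl sulfur. Going by the values given here, since no measured step speaks to this change, the step from compound 1 to compound 4 is expected to stay within the usual scatter in this assay, with no direction favoured. Compound 4 is therefore estimated at 5000 nM in this assay, within a range of 1000 nM to 20000 nM, which corresponds to an expected step that the limit leaves unreadable from compound 1 to compound 4.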

Compound 4, inhibition constant: < 10000 nM
Compound 4 ended at the assay's limit (the forecaster's own chance of this, stated with the estimate: 50%); the middle value does not contradict the limit.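

Compound 1 and compound 4 are each known in this assay only as a limit, so no step between them can be read: the limit of < 10000 nM in this assay, at which 2 of the 4 values shown sit.

On these data alone, whether isopropyl in place of propyl on a sulfonyl sulfur moves the value, and in which direction, stays open.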